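Trimming the Chain of Compound 2

This account rests on a few compounds, and the source may have more. Where it says the series, first, only, none or still open, it means among the compounds named here.

In a functional assay on MGC-803 cells (Homo sapiens) for inhibition, read by MTT assay, with a stated time of 48 h (on this read-out lower numbers stand for stronger inhibition and higher numbers for weaker inhibition), compound 1 `COc1ccc(CN(C(C)=O)c2cc(OC)c(OC)c(OC)c2)cc1O` gives 79 nM and compound 2 `CCC/C=C/C(=O)N(Cc1ccc(OC)c(O)c1)c1cc(OC)c(OC)c(OC)c1` gives 70 nM. Among the measured compounds shown here, these two values lie within the usual scatter of each other, so compound 2 cannot be told apart from compound 1 on the numbers so far. Compound 3 `CC/C=C/C(=O)N(Cc1ccc(OC)c(O)c1)c1cc(OC)c(OC)c(OC)c1` has not yet been measured. Its difference from compound 2 is hydrogen in place of methyl on a saturated chain carbon, two bonds along the chain from a double-bonded chain carbon: pent-1-en-1-yl becomes but-1-en-1-yl. For the measured compounds named here, one measured step bears on this, a 1.1-fold lower number from compound 1 to compound 2 (0.05 log units; within the scatter), where pent-1-en-1-yl took the place of methyl without a shift beyond the scatter. Compound 3 removes only a small part of that chain, so no real shift in either direction is expected in this assay, though a single step is thin evidence. The expected step is a 1.0-fold higher number from compound 2 to compound 3 (0.01 log units; within the scatter), which would stay within the scatter. For compound 3 the estimated value is 72 nM, with an expected range from 35 nM to 150 nM.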

Compound 3, half-maximal inhibitory concentration: 58 nM
Estimate against measurement, compound 3: 1.2-fold (0.09 log units) above, and the stated range covers the measured number.
By their numbers in this assay, from the lowest: compounds 3, 2 and 1 (each within the scatter of the next).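

Taking the methyl off this saturated chain carbon gives a 1.2-fold lower number from compound 2 to compound 3 (0.08 log units; within the scatter) in this assay and so shows that this chain can lose one carbon with no shift the read-out can separate from scatter. The shorter chain also stays close to the plain methyl on the carbonyl carbon, with a 1.4-fold lower number from compound 1 to compound 3 (0.13 log units; within the scatter) as the step, so neither but-1-en-1-yl nor pent-1-en-1-yl can be told apart from methyl at this place. Nothing available explains why these changes leave the number within the scatter.

Still open, from the compounds shown here alone, is whether any group on this carbonyl carbon can move the number beyond the scatter, as a much longer chain, an amine or a carboxylic acid at the chain end might. Going by these compounds, the role of the double bond is also open, and a saturated butyl chain would test it directly.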